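Compound 3 to compound 4: shifting one methyl on the dimethylphenyl

The compounds below may be only part of what the source reports. "The series", "measured", "known", "first", "only" and "open" are said of these compounds alone.

Values in an ADME assay on microsomes from liver (Rattus norvegicus) for metabolic stability, read by LC-MS, using NADPH, at 37 degrees C (a higher number here means that the compound lasts longer, a lower number that the compound disappears faster), are as follows.
Compound 1 `Cc1cccc(F)c1-c1nc(CN2CCC(C(=O)NCCCN3C[C@H](C)C[C@H](C)C3)CC2)c(C)o1` gives 0.0733 h here.
Compound 2 `COc1cccc(Cl)c1-c1nc(CN2CCC(C(=O)NCCCN3C[C@H](C)C[C@H](C)C3)CC2)c(C)o1` gives 0.055 h here.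
Compound 3 `Cc1ccc(-c2nc(CN3CCC(C(=O)NCCCN4C[C@H](C)C[C@H](C)C4)CC3)c(C)o2)cc1C` gives > 0.5 h as a limit.

Compound 3 is held only as a limit (> 0.5 h) and not as a number. Compound 4 `Cc1ccc(-c2nc(CN3CCC(C(=O)NCCCN4C[C@H](C)C[C@H](C)C4)CC3)c(C)o2)c(C)c1` carries 2,4-dimethylphenyl in place of 3,4-dimethylphenyl (2,4-dimethylphenyl in place of 3,4-dimethylphenyl on an aromatic carbon) on the shared core. Within the data shown here, two measured steps bear on this: an at least 6.8-fold higher number from compound 1 to compound 3 (0.83 log units; beyond the scatter) and an at least 9.0-fold higher number from compound 2 to compound 3 (0.95 log units; beyond the scatter) are both beyond the scatter, whereas a 1.3-fold lower number from compound 1 to compound 2 (0.12 log units; within the scatter) lies within it. The 2-fluoro-6-methylphenyl of compound 1 and the 2-chloro-6-methoxyphenyl of compound 2 share a group at the 2 position with 2,4-dimethylphenyl, so part of an at least 9.0-fold higher number from compound 2 to compound 3 (0.95 log units; beyond the scatter) is expected to be lost. The expected change is a fall in this assay (an at least 2.5-fold lower number from compound 3 to compound 4 (0.39 log units; beyond the scatter)). The estimated value for compound 4 is 0.2 h (expected range 0.07 h to 0.6 h).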

Compound 4, half-life: > 0.5 h
Compound 4: no number, only a limit; the forecaster's own chance of this, stated with the estimate: 20%; middle value at least 2.5-fold (0.39 log units) away from the limit.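

In this assay compound 4 is held only as a limit, > 0.5 h, and not as a number. The 2,4-dimethylphenyl group, with its single methyl in place of the two groups of the earlier phenyls, does not bring back the short half-lives, with an at least 6.8-fold higher number from compound 1 to compound 4 (0.83 log units; beyond the scatter) and an at least 9.0-fold higher number from compound 2 to compound 4 (0.95 log units; beyond the scatter). The step between compound 3 and compound 4 cannot be read, so the two dimethylphenyl groups cannot be ranked.

As far as these compounds go, whether a pyridine in place of the phenyl would hold up in the same way stays open. The true half-lives of compound 3 and compound 4 also stay open: the limit of > 0.5 h in this assay, at which 2 of the 4 values shown sit.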